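Replacing a dioxolane ring with a short hydroxyethyl chain

The compounds below may be only part of what the source reports. "The series", "measured", "known", "first", "only" and "open" are said of these compounds alone.

Three compounds share a core in which a naphthalene is joined to a triazole, and they differ only in the group carried on a saturated chain carbon bound to an aromatic nitrogen. In a functional assay on B16 cells (Mus musculus) for cytotoxicity, read by MTT assay, with a stated time of 48 h (on this read-out higher numbers stand for weaker inhibition and lower numbers for stronger inhibition), compound 2 `CC1(C)OCC(Cn2cc(-c3ccc4ccccc4c3)nn2)O1` gives 6600 nM, the lowest of the two numbers available. Compound 3 `CC1(C)OCC(Cn2cc(C(O)c3ccc4ccccc4c3)nn2)O1` gives 26900 nM in this assay. Compound 1 `CCOC(=O)Cn1cc(-c2ccc3ccccc3c2)nn1` reaches only a limit of this assay, > 100000 nM, so no number is available for it. For the measured compounds named here, the one measured step, an at least 15-fold lower number from compound 1 to compound 2 (1.18 log units; beyond the scatter), shows that swapping the group at this position can move the number a long way, as far as the assay limit of > 100000 nM in this assay, at which 1 of the 3 values shown sits, allows one to judge.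

Compound 4 `OCCCn1cc(-c2ccc3ccccc3c2)nn1` has not yet been measured. It differs from compound 2 by 2-hydroxyethyl in place of 2,2-dimethyl-1,3-dioxolan-4-yl on a saturated chain carbon bound to an aromatic nitrogen. Going by the values given here, no measured step covers this exact swap, so the expectation is weak. The step is expected to be a 3.0-fold higher number from compound 2 to compound 4 (0.48 log units; beyond the scatter), towards a higher number. Compound 4 is therefore estimated at 20000 nM, with a range from 5000 nM to 100000 nM.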

Compound 4, half-maximal inhibitory concentration: > 100000 nM
Compound 4: only a limit was reported (the forecaster's own chance of this, stated with the estimate: 25%); middle value at least 5.0-fold (0.69 log units) away from the limit.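

The value for compound 4 is a limit of this assay, not a number. Putting 2-hydroxyethyl in place of 2,2-dimethyl-1,3-dioxolan-4-yl still gives a readable step, an at least 15-fold higher number from compound 2 to compound 4 (1.18 log units; beyond the scatter), so a second group on this saturated chain carbon, after the ethoxycarbonyl of compound 1, gives no number, and among compound 1, compound 2 and compound 4 only the ring-bearing compound 2 does. The step between compound 1 and compound 4 cannot be read, and how far the others reach stays capped: the limit of > 100000 nM in this assay, at which 2 of the 4 values shown sit.

The compounds shown leave open whether the ring as such matters or only some part of it. A 2,3-dihydroxypropyl group, an amine or a longer chain at this place could help separate those possibilities.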